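A Ring Exchange on a Saturated Chain Carbon

A few compounds are considered here, and "the series" means these few. Any claim that something is new, unique, unknown or untested is made for them only; others in the source may bear on it.

Compound 1 `CC(C)C(/C=C1\NC(=O)NC1=O)c1ccc(-c2ccc3cccc(F)c3c2)[nH]c1=O` – 10700 nM
Compound 2 `CC(C)[C@@H](c1ccc(-c2ccc3cccc(F)c3c2)[nH]c1=O)[C@@H]1OC(=O)NC1=O` – 27400 nM
Compound 3 `CCC(CC)C(/C=C1\OC(=O)NC1=O)c1ccc(-c2ccc3cccc(F)c3c2)[nH]c1=O` – 33700 nM

In a physicochemical assay for solubility, in phosphate buffer, measured as kinetic solubility (a higher number here means a more soluble compound, a lower number a less soluble compound), compound 1 gives 10700 nM, the lowest of the three numbers, and the gaps up to compound 2 and compound 3 both lie beyond the scatter.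

Compound 4 `CC(C)C(c1ccc(-c2ccc3cccc(F)c3c2)[nH]c1=O)C1SC(=O)NC1=O` has not yet been measured. It differs from compound 1 as follows: a group of 7 heavy atoms (3 carbon, 1 nitrogen, 2 oxygen, 1 sulfur; one five-membered non-aromatic ring with 2 hetero atoms) in place of a group of 8 heavy atoms (4 carbon, 2 nitrogen, 2 oxygen; one five-membered non-aromatic ring with 2 hetero atoms), on a saturated chain carbon bound to an aromatic carbon and a saturated chain carbon. The group that enters is 2,4-dioxo-1,3-thiazolidin-5-yl, on a saturated chain carbon bound to an aromatic carbon and a saturated chain carbon.

Among the compounds with values here, no measured pair isolates this change, so the expectation rests on indirect evidence. Compound 2 also carries a five-membered non-aromatic ring directly on such a saturated chain carbon, and in this assay compound 2 gives 27400 nM. Compound 3 lacks that arrangement, yet compound 3 gives 33700 nM, so three compounds establish no rule. A small upward step is therefore expected, one not clearly beyond the scatter, and the estimated step is a 1.9-fold higher number from compound 1 to compound 4 (0.27 log units; within the scatter). The estimate for compound 4 is 20000 nM, with an expected range from 8000 nM to 45000 nM.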

Compound 4, solubility: 20100 nM
Beside the measured number, compound 4's estimate is 1.0-fold (0.00 log units) below it; measured number inside the range.
By their numbers in this assay, from the lowest: compounds 1, 4, 2 and 3 (each within the scatter of the next, the first and the last beyond it).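

Within the data shown here, compound 4 gives the first step in this set that can be read at a single place: in this assay the exchange for 2,4-dioxo-1,3-thiazolidin-5-yl, on a saturated chain carbon bound to an aromatic carbon and a saturated chain carbon, amounts to a 1.9-fold higher number from compound 1 to compound 4 (0.27 log units; within the scatter) and so stays inside the usual spread of repeated measurements. The two groups are not alike by the counts: the entering one brings sulfur into the five-membered non-aromatic ring and differs in heavy atoms, in double bonds outside aromatic rings and in hydrogen-bond donors and acceptors, yet at this position these differences together leave compound 1 and compound 4 indistinguishable in this read-out. No measurement offered here explains the result or assigns any part of it to a single feature of either group. The compounds shown leave open how a carboxylic acid or an amine on the same saturated chain carbon would read in this assay when set against compound 1. They also leave open whether the same exchange would read alike with a longer chain on that carbon.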